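Swapping chlorine for bromine on compound 3

The compounds below may be only part of what the source reports. "The series", "measured", "known", "first", "only" and "open" are said of these compounds alone.

- Compound 1 `COc1cccc(/C=C2\SC(=S)N(NS(=O)(=O)c3ccccc3)C2=O)c1`: > 50000 nM (a limit)
- Compound 2 `O=C1/C(=C/c2ccc(Cl)c(F)c2)SC(=S)N1NS(=O)(=O)c1ccccc1`: > 50000 nM (a limit)
- Compound 3 `O=C1/C(=C/c2ccc(Cl)c(Cl)c2)SC(=S)N1NS(=O)(=O)c1ccccc1`: > 50000 nM (a limit)

In a functional assay on ECV-304 cells (Homo sapiens) for cytotoxicity (on this read-out higher numbers stand for weaker inhibition and lower numbers for stronger inhibition), compound 3 gives > 50000 nM, which is a limit and not a number. It shares that result with the other two measured compounds: the limit of > 50000 nM in this assay, at which 3 of the 3 values shown sit. Compound 3 therefore has no exact position among them.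

Compound 4 `O=C1/C(=C/c2ccc(Br)c(Br)c2)SC(=S)N1NS(=O)(=O)c1ccccc1` carries 3,4-dibromophenyl in place of 3,4-dichlorophenyl on a double-bonded chain carbon bound to a double-bonded ring carbon. The closest guide is a step that the two limits leave unreadable from compound 2 to compound 3, and a step that the two limits leave unreadable from compound 1 to compound 3 and a step that the two limits leave unreadable from compound 1 to compound 2 also bear on it. None of these steps has a readable size, but all three changes left the result in this assay at the same limit. No step beyond the scatter, in either direction, is therefore expected, and another limit is the likeliest outcome. The expected change is a number no higher from compound 3 to compound 4 (the limit leaves the size open). For compound 4 the estimated value is 50000 nM, within an expected range of 25000 nM to 100000 nM.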

Compound 4, half-maximal inhibitory concentration: > 50000 nM
Compound 4: only a limit was reported; the forecaster's own chance of this, stated with the estimate: 85%; the middle value lies on the limit itself.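

Going by these compounds alone, compound 4 gives > 50000 nM in this assay, a limit and not a number, so no step from compound 1, compound 2 or compound 3 to compound 4 can be read. The compounds shown leave open the exact value of each of the four in this assay, and whether any group on the double-bonded chain carbon would give a readable number.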